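Extending the aryl ketone of compound 2 to a styryl ketone

A few compounds are considered here, and "the series" means these few. Any claim that something is new, unique, unknown or untested is made for them only; others in the source may bear on it.

Two compounds of the series have numbers in an assay on isolated protein for binding affinity to histamine H2 receptor (Homo sapiens); a lower number here means a stronger inhibitor, a higher number a weaker inhibitor. Compound 1 `CCOC(=O)N1CCN(CCCOc2ccc(C(=O)C3CC3)cc2)CC1` carries a cyclopropyl on the carbonyl carbon and in this assay compound 1 gives 79400 nM. Compound 2 `CCOC(=O)N1CCN(CCCOc2ccc(C(=O)c3ccc(OC)cc3)cc2)CC1` carries a 4-methoxyphenyl there instead, and in this assay compound 2 gives 8320 nM. Among the measured compounds shown here, the single measured step, a 9.5-fold lower number from compound 1 to compound 2 (0.98 log units; beyond the scatter), is the only comparison available, so compound 2 stands with the lowest of the two numbers, the other being compound 1.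

Compound 3 `CCOC(=O)N1CCN(CCCOc2ccc(C(=O)/C=C/c3ccc(OC)cc3)cc2)CC1` keeps the shared core and differs from compound 2 only in 2-(4-methoxyphenyl)ethenyl in place of 4-methoxyphenyl on a carbonyl carbon. For the measured compounds named here, no measured step concerns inserting an ethenyl link between a carbonyl and an aryl ring; the step from compound 1 to compound 2 shows only that a 4-methoxyphenyl in this place is preferred over a cyclopropyl, and it cannot be read across directly. The expectation for compound 3 is therefore a step of modest size at most, with the direction uncertain and a somewhat lower number slightly favoured. The expected step is a 1.7-fold lower number from compound 2 to compound 3 (0.22 log units; within the scatter). Compound 3 is thus estimated at 5000 nM, with a range from 1500 nM to 20000 nM.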

Compound 3, inhibition constant: 6760 nM
The estimate for compound 3 lay 1.4-fold (0.13 log units) below the measured number, within the range that was stated.
By their numbers in this assay, from the lowest: compounds 3 and 2 (each within the scatter of the next); then compound 1.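

In this assay, the position on the carbonyl carbon accepts 2-(4-methoxyphenyl)ethenyl in place of 4-methoxyphenyl with no change that can be read, at a 1.2-fold lower number from compound 2 to compound 3 (0.09 log units; within the scatter), so inserting the ethenyl link between the carbonyl and the aryl ring neither helps nor harms on this measure. The advantage over cyclopropyl is kept with the longer group, at a 12-fold lower number from compound 1 to compound 3 (1.07 log units; beyond the scatter), which shows that both groups carrying the 4-methoxyphenyl ring stand apart from cyclopropyl, and that this separation does not depend on the ring sitting directly on the carbonyl carbon. Nothing is available on why the two groups cannot be told apart, or on why either differs from cyclopropyl.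

The compounds shown leave open whether the double bond itself matters, which a saturated 2-(4-methoxyphenyl)ethyl group on the carbonyl carbon would test. They also leave open whether the methoxy group contributes to the number at all, as a comparison with an unsubstituted phenyl, or with a hydroxyl or an amine in its place, would show.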